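Bromo in place of methoxy on an aromatic carbon

The source may report more compounds than this note shows. Statements on the series, on what has been measured and on what is new or still open speak of the compounds shown alone.

In a functional assay on MCF7 cells (Homo sapiens) for antiproliferative activity, read by MTT assay, with a stated time of 72 h (on this read-out lower numbers stand for stronger inhibition and higher numbers for weaker inhibition), compound 1 (`CCC(=O)NNC(=O)c1csc2ncc(-c3ccc(OC)cc3)n12`) gives 53200 nM. Compound 2 (`CCCC(=O)NNC(=O)c1csc2ncc(-c3ccc(OC)cc3)n12`), the other measured compound, gives 32800 nM. These two values lie within the scatter of each other, so compound 2 holds no distinct place in this small set.

Compound 3 (`CCCC(=O)NNC(=O)c1csc2ncc(-c3ccc(Br)cc3)n12`) differs from compound 2 as follows: bromo in place of methoxy on an aromatic carbon. This puts bromo in place of methoxy on an aromatic carbon, para to a large group, turning 4-methoxyphenyl into 4-bromophenyl.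

Among the compounds with values here, only one measured step is available, a 1.6-fold lower number from compound 1 to compound 2 (0.21 log units; within the scatter). It is a methyl in place of hydrogen on a saturated chain carbon, so it lies away from the aromatic ring and bears on the new change only indirectly. Within the data shown here, no measured compound carries a different group at the aromatic position, and the data therefore give no direction for this change. No step beyond the scatter is expected in this assay. The expected step is a 1.3-fold lower number from compound 2 to compound 3 (0.12 log units; within the scatter). Compound 3 is estimated at 25000 nM, with an expected range from 9000 nM to 60000 nM.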

Compound 3, half-maximal inhibitory concentration: 27500 nM
Compound 3: the middle estimate sits 1.1-fold (0.04 log units) below what was measured; low and high end bracket the measured number.
By their numbers in this assay, from the lowest: compounds 3, 2 and 1 (each within the scatter of the next).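

In this assay, the first variation at this aromatic carbon gives a 1.2-fold lower number from compound 2 to compound 3 (0.08 log units; within the scatter), so compound 2 and compound 3 cannot be told apart. The earlier compounds shown here varied only the saturated chain and said nothing about this position, whereas this pair shows that methoxy, with its hydrogen-bond acceptor, can give way to bromo, which has none, without the number leaving the scatter. Nothing measured here offers an explanation for this outcome.

As far as these compounds go, one exchange at one position cannot show whether this aromatic carbon is generally tolerant, and it remains open whether an amine, a carboxylic acid or a nitrile in the same place would move the number beyond the scatter. Within the data shown here, it is also open whether bromo would read the same alongside the shorter chain of compound 1, and whether a longer chain in place of the one carried by compound 2 and compound 3 would shift the number in this assay.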